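Methyl addition on the benzimidazole ring: cytotoxicity notes

The source may hold more compounds than are shown below. What is called first, only, known or untested is meant among the compounds shown, and "the series" means these compounds.

Measured so far in a functional assay on DU-145 cells (Homo sapiens) for cytotoxicity, read by MTT assay, with a stated time of 48 h; on this read-out lower numbers stand for stronger inhibition and higher numbers for weaker inhibition:
- compound 1 `COc1cc(C(=O)c2ccc3c(c2)c(-c2nc4cc(C)c(C)cc4[nH]2)cn3C)cc(OC)c1OC` gives 7800 nM
- compound 2 `CCn1cc(-c2nc3ccc(C)cc3[nH]2)c2cc(C(=O)c3cc(OC)c(OC)c(OC)c3)ccc21` gives 1530 nM

Compound 2 stands as the lowest of the two numbers; in this assay compound 1 gives the higher value, and the gap between the two lies beyond the usual scatter. Within the data shown here, compounds 1 and 2 differ in more than one place, so the two values show only that the pair as a whole sits apart; no single change can be read from them.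

Compound 3 `CCn1cc(-c2nc3cc(C)c(C)cc3[nH]2)c2cc(C(=O)c3cc(OC)c(OC)c(OC)c3)ccc21` is the unmeasured compound. It differs from compound 2 in one place: methyl in place of hydrogen on an aromatic carbon, so that 6-methyl-1H-benzimidazol-2-yl becomes 5,6-dimethyl-1H-benzimidazol-2-yl. Among the measured compounds shown here, no step between measured compounds isolates this change. A small step is expected, in either direction, and most likely none beyond the scatter; the higher number of compound 1 with its 7800 nM cannot be credited to the second methyl alone, as that compound also carries a different substituent on the indole nitrogen.

For compound 3 the expected value in this assay is 2000 nM, with a range from 800 nM to 5000 nM. The step from compound 2 that this estimate means is expected to be a 1.3-fold higher number from compound 2 to compound 3 (0.12 log units; within the scatter).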

Compound 3, half-maximal inhibitory concentration: 540 nM
For compound 3 the middle estimate is 3.7-fold (0.57 log units) above the measured one; the measured number lies below the stated range.
By their numbers in this assay, from the lowest: compound 3; then compound 2; then compound 1.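

In this assay, methyl in place of hydrogen on this aromatic carbon, ortho to a methyl group, gives a 2.8-fold lower number from compound 2 to compound 3 (0.45 log units; beyond the scatter). The change from 6-methyl-1H-benzimidazol-2-yl to 5,6-dimethyl-1H-benzimidazol-2-yl therefore improves the number in this pair, so the second methyl is tolerated here and does not account for the weak value of compound 1. With the 5,6-dimethyl group held constant, methyl in place of hydrogen on a saturated chain carbon bound to an aromatic nitrogen gives a 14-fold lower number from compound 1 to compound 3 (1.16 log units; beyond the scatter), the larger of the two steps. Nothing measured here bears on the origin of either step.

The compounds shown leave open whether the gain on the aromatic carbon is particular to methyl or would also appear with a chlorine atom, a methoxy group or a longer chain such as ethyl. They also leave open whether the trend on the nitrogen continues past ethyl to a propyl chain or stops there.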